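Replacing a ring on compound 1 with piperidin-1-yl

This account rests on a few compounds, and the source may have more. Where it says the series, first, only, none or still open, it means among the compounds named here.

Among the compounds with values here, in a functional assay on SK-BR-3 cells (Homo sapiens) for cytotoxicity, read by MTT assay, with a stated time of 72 h (on this read-out higher numbers stand for weaker inhibition and lower numbers for stronger inhibition), compound 1 `N[C@H]1CC[C@H](Nc2c(C(=O)NCc3ccc(F)cc3)nc(N3CCCCS3(=O)=O)c3cccnc23)CC1` gives 8500 nM, the highest of the three numbers measured so far. Compound 2 `CC(C)(C)OC(=O)N1CCN(c2c(C(=O)NCc3ccc(F)cc3)nc(Br)c3cccnc23)CC1` gives 3000 nM and compound 3 `Nc1ccc(Nc2c(C(=O)NCc3ccc(F)cc3)nc(Br)c3cccnc23)cc1` gives 4000 nM. These two values lie within the scatter of each other, and both lie lower than that of compound 1 by more than the scatter.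

The next compound to be tested is compound 4 `N[C@H]1CC[C@H](Nc2c(C(=O)NCc3ccc(F)cc3)nc(N3CCCCC3)c3cccnc23)CC1`, which differs from compound 1 in one place: a group of 6 heavy atoms (5 carbon, 1 nitrogen; one six-membered non-aromatic ring with 1 hetero atom) in place of a group of 8 heavy atoms (4 carbon, 1 nitrogen, 2 oxygen, 1 sulfur; one six-membered non-aromatic ring with 2 hetero atoms), on an aromatic carbon. The piperidin-1-yl group enters on an aromatic carbon, next to the ring nitrogen and para to a (4-aminocyclohexyl)amino group.

Within the data shown here, no measured pair isolates this change, and compounds 2 and 3 differ from compound 1 in more than one place, so the evidence is indirect. Neither of them carries the ring that leaves, and both give lower numbers, as seen with compound 3 at 4000 nM. A moderate move toward stronger inhibition is therefore expected in this assay, though no change beyond the scatter remains possible. The estimate is a 2.1-fold lower number from compound 1 to compound 4 (0.33 log units; beyond the scatter). For compound 4 the expected value is 4000 nM, with an estimated range from 1600 nM to 10000 nM.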

Compound 4, half-maximal inhibitory concentration: > 10000 nM
Compound 4 was reported as a limit; the forecaster's own chance of this, stated with the estimate: 3%; middle value at least 2.5-fold (0.39 log units) from the limit.
By their numbers in this assay, from the lowest: compounds 2 and 3 (each within the scatter of the next); then compound 1. At a limit, above all of these: compound 4.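

Compound 1 and compound 4 are the first pair shown that differs only at this position, the aromatic carbon next to the ring nitrogen and para to a (4-aminocyclohexyl)amino group, so this one ring exchange can now be read directly in this assay. The exchange gives an at least 1.1-fold higher number from compound 1 to compound 4 (0.07 log units; that floor lies within the scatter), which means piperidin-1-yl brings no move toward stronger inhibition at this position, although the floor of the step does not by itself establish a real loss. Compound 4 gives > 10000 nM, which is a limit of the assay and not a number, and how far the step extends past its floor cannot be read: the limit of > 10000 nM in this assay, at which 1 of the 4 values shown sits.

The compounds shown leave open how this assay would read with other groups at this position, such as a morpholin-4-yl ring, a small open-chain amine or a bromine atom alongside the (4-aminocyclohexyl)amino group. They also leave open whether the sulfur atom or its two oxygen atoms account for the difference between the two rings, a question that a ring keeping the sulfur without those oxygens would address.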